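Moving the trifluoromethyl group around the aryl ring

A few compounds are considered here, and "the series" means these few. Any claim that something is new, unique, unknown or untested is made for them only; others in the source may bear on it.

Within the data shown here, compound 2 `Cc1nc(-c2ccccc2)c(C(=O)N2CCN(c3cccc(C(F)(F)F)c3)CC2)o1` gives 153 nM in a functional assay on HL-60 cells (Homo sapiens) for inhibition, read by MTT assay, with a stated time of 72 h (on this read-out lower numbers stand for stronger inhibition and higher numbers for weaker inhibition), the highest of the two numbers so far, and compound 1 `Cc1nc(-c2ccccc2)c(C(=O)N2CCN(c3ccc(Cl)c(Cl)c3)CC2)o1` gives 124 nM, a difference within the scatter. Among the measured compounds shown here, the only measured step that changes the aryl group on the ring nitrogen is a 1.2-fold higher number from compound 1 to compound 2 (0.09 log units; within the scatter), which barely moved the read-out. Compound 3 `Cc1nc(-c2ccccc2)c(C(=O)N2CCN(c3ccc(C(F)(F)F)cc3)CC2)o1` carries the change (4-(trifluoromethyl)phenyl in place of 3-(trifluoromethyl)phenyl on an amine nitrogen in a ring). Because a 1.2-fold higher number from compound 1 to compound 2 (0.09 log units; within the scatter) stayed within the scatter, no shift beyond the scatter is expected, so compound 3 is estimated at 150 nM, ranging from 60 nM to 400 nM, a step of a 1.0-fold lower number from compound 2 to compound 3 (0.01 log units; within the scatter).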

Compound 3, half-maximal inhibitory concentration: > 1000 nM
Compound 3 ended at the assay's limit; the forecaster's own chance of this, stated with the estimate: 3%; middle value at least 6.6-fold (0.82 log units) from the limit.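

In this assay compound 3 gives > 1000 nM, which is a limit of the assay and not a number: the limit of > 1000 nM in this assay, at which 1 of the 3 values shown sits. Among these compounds, the placing of the trifluoromethyl group on the aryl ring therefore matters in a way the earlier compounds did not show: with the same atoms joined differently, 4-(trifluoromethyl)phenyl in place of 3-(trifluoromethyl)phenyl gives an at least 6.5-fold higher number from compound 2 to compound 3 (0.81 log units; beyond the scatter), and in place of 3,4-dichlorophenyl it gives an at least 8.0-fold higher number from compound 1 to compound 3 (0.90 log units; beyond the scatter), while the one earlier step stayed within the scatter. From the compounds shown here alone, it remains open how a plain phenyl, a methoxyphenyl or a pyridine ring on the same ring nitrogen would read.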